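From carbamoylmethyl to 1-carboxyethyl: compound 1 to compound 4

The compounds below may be only part of what the source reports. "The series", "measured", "known", "first", "only" and "open" are said of these compounds alone.

compound 1 `C/C(=N\OCC(N)=O)c1ccc(Cl)cc1`: 24 mg/kg
compound 2 `C/C(=N\OCC(N)=O)c1ccc(Cl)c(Cl)c1`: 55 mg/kg
compound 3 `C/C(=N\OCCCC(=O)O)c1ccc(Cl)cc1`: 58 mg/kg

In a functional assay on the whole organism for inhibition, with Rattus norvegicus as the target, read by paw edema, with stated times of 1 h and 3 h (a higher number here means that more compound is needed for the effect, a lower number that less compound is needed), compound 1 has the lowest number of the three, and both other compounds lie beyond the scatter from it. Compound 4 `C/C(=N\OC(C)C(=O)O)c1ccc(Cl)cc1` differs from it as follows: 1-carboxyethyl in place of carbamoylmethyl on an oxygen. This puts 1-carboxyethyl in place of carbamoylmethyl on an oxygen. The measured change closest to this is 2-carboxyethyl in place of carbamoyl, a modest step: a 2.4-fold higher number from compound 1 to compound 3 (0.38 log units; beyond the scatter). Chloro in place of hydrogen on an aromatic carbon lies elsewhere in the structure and bears less directly: a 2.3-fold higher number from compound 1 to compound 2 (0.36 log units; beyond the scatter). A modest step to a higher number is therefore expected in this assay, as compound 3 gives 58 mg/kg. The expected step is a 2.1-fold higher number from compound 1 to compound 4 (0.32 log units; beyond the scatter). For compound 4 the estimated value is 50 mg/kg, with an expected range of 20 mg/kg to 120 mg/kg.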

Compound 4, dose for half-maximal effect: 55 mg/kg
Compound 4: the middle estimate sits 1.1-fold (0.04 log units) below what was measured, and the stated range covers the measured number.
By their numbers in this assay, from the lowest: compound 1; then compounds 2, 4 and 3 (each within the scatter of the next).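

Placing 1-carboxyethyl on the oxygen in place of carbamoylmethyl gives a 2.3-fold higher number from compound 1 to compound 4 (0.36 log units; beyond the scatter) in this assay, so a second acid-bearing chain also stands apart from compound 1. Compound 3 at 58 mg/kg and compound 4 at 55 mg/kg lie within the scatter of each other, so these two chains are not separated in this assay. No measurement on hand accounts for the step.

From the compounds shown here alone, whether the step follows the carboxylic acid or the extra methyl of 1-carboxyethyl remains open. Carboxymethyl and 1-carbamoylethyl on the same oxygen would separate these two changes.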